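Nitro in place of fluoro: notes ahead of compound 3

A few compounds are considered here, and "the series" means these few. Any claim that something is new, unique, unknown or untested is made for them only; others in the source may bear on it.

compound 1 `C/C(=N\NC(=S)Nc1ccc(F)cc1)c1ccccn1`: 1.2 nM
compound 2 `C/C(=N/NC(=S)Nc1ccc(F)cc1)c1ccccn1`: 1.2 nM

Compound 1, with 1.2 nM in a functional assay on MCF7 cells (Homo sapiens) for cytotoxicity, read by MTT assay, with a stated time of 48 h (a lower number here means a stronger inhibitor, a higher number a weaker inhibitor), stands level with compound 2, which gives 1.2 nM in this assay. Among the measured compounds shown here, the only step measured so far, no change at the digits printed from compound 1 to compound 2 (within the scatter), is a change of drawn geometry alone, as the fact that compounds 1 and 2 differ only in the configuration as drawn records, and it leaves the read-out untouched.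

The next compound, compound 3 `C/C(=N\NC(=S)Nc1ccc([N+](=O)[O-])cc1)c1ccccn1`, keeps the shared core of compound 1 and changes the substituent on the six-membered aromatic ring of carbon only: nitro in place of fluoro on an aromatic carbon. For the measured compounds named here, no measured step touches this kind of change; the one step in hand concerns configuration and not a ring substituent, so it gives no direction for the size or sign of the move in this assay. The expectation therefore rests on compound 1 alone, with a wide range in both directions.

On that basis compound 3 is expected to give about 1.5 nM in this assay, between 0.4 nM and 6 nM. The step expected is a 1.3-fold higher number from compound 1 to compound 3 (0.10 log units; within the scatter), which may well fall within the scatter.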

Compound 3, half-maximal inhibitory concentration: 52 nM
For compound 3 the middle estimate is 35-fold (1.54 log units) below the measured one; measured number above the stated range.
By their numbers in this assay, from the lowest: compounds 1 and 2 (each within the scatter of the next); then compound 3.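

Working notes on the ring position. Among the compounds shown here, this is the first place where a single change moves the read-out: in this assay, on an aromatic carbon of the six-membered aromatic ring of carbon only, para to a large group, nitro in place of fluoro gives a 43-fold higher number from compound 1 to compound 3 (1.64 log units; beyond the scatter). For the compounds shown here, the only earlier step, no change at the digits printed from compound 1 to compound 2 (within the scatter), concerned drawn geometry alone and said nothing about this position, so the substituent here is now known not to be indifferent in this assay, at least for this one exchange. What the compounds shown record offers no explanation for the size or the direction of this step.

Only fluoro and nitro are shown at this position, so it remains open whether fluoro is itself favourable or nitro is unfavourable, and where an amine, a methoxy group or a carboxylic acid at the same place would fall. As far as these compounds go, it also remains open whether nitro in place of fluoro would give a step of similar size in the drawn geometry of compound 2.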